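Changing the amide group of compound 3

A few compounds are considered here, and "the series" means these few. Any claim that something is new, unique, unknown or untested is made for them only; others in the source may bear on it.

Measured in a functional assay on PC-3 cells (Homo sapiens) for antiproliferative activity, read by MTT assay, with a stated time of 48 h; on this read-out lower numbers stand for stronger inhibition and higher numbers for weaker inhibition:
compound 1 `CCn1c(C(=O)NCC#N)ccc1C(CC)(CC)c1ccc(OCCC(O)(CC)CC)c(C)c1` - 17800 nM
compound 2 `CCn1c(C(=O)Nc2ccc(OC(F)(F)F)cc2)ccc1C(CC)(CC)c1ccc(OCCC(O)(CC)CC)c(C)c1` - > 50000 nM
compound 3 `CCOC(=O)CN(C)C(=O)c1ccc(C(CC)(CC)c2ccc(OCCC(O)(CC)CC)c(C)c2)n1CC` - 7140 nM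

Compound 2 gives > 50000 nM, which is a limit of the assay and not a number. Compound 3 has the lower of the two actual numbers. Compound 4 `CCn1c(C(=O)NC(CO)CCO)ccc1C(CC)(CC)c1ccc(OCCC(O)(CC)CC)c(C)c1` differs from it on a carbonyl carbon (a group of 7 heavy atoms (4 carbon, 1 nitrogen, 2 oxygen; no ring) in place of a group of 8 heavy atoms (5 carbon, 1 nitrogen, 2 oxygen; no ring), on a carbonyl carbon). Two measured steps at that carbon bear on this: a 2.5-fold lower number from compound 1 to compound 3 (0.40 log units; beyond the scatter) and an at least 7.0-fold lower number from compound 2 to compound 3 (0.84 log units; beyond the scatter). In both, the amide hydrogen is lost. Compound 4 regains that hydrogen, and its new group has no ring, so compound 1 at 17800 nM is the closer guide. In this assay the expected change is therefore a 2.2-fold higher number from compound 3 to compound 4 (0.35 log units; beyond the scatter) and no more than modest. For compound 4 the estimate is 16000 nM (expected range 5000 nM to 45000 nM).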

Compound 4, half-maximal inhibitory concentration: 8760 nM
Beside the measured number, compound 4's estimate is 1.8-fold (0.26 log units) above it; measured number inside the range.
By their numbers in this assay, from the lowest: compounds 3 and 4 (each within the scatter of the next); then compound 1. At a limit, above all of these: compound 2.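

With the amide hydrogen back, compound 4 stays level with compound 3 in this assay, so that hydrogen alone does not set the number here: a 1.2-fold higher number from compound 3 to compound 4 (0.09 log units; within the scatter). Among the amides that keep this hydrogen, the group on nitrogen still counts, with a 2.0-fold lower number from compound 1 to compound 4 (0.31 log units; beyond the scatter) and an at least 5.7-fold lower number from compound 2 to compound 4 (0.75 log units; beyond the scatter). Compound 2 sits at a limit of the assay, not at a number: the limit of > 50000 nM in this assay, at which 1 of the 4 values shown sits. Going by these compounds, what a carboxylic acid or an amine at the end of this amide group would give stays open.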